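The compounds below may be only part of what the source reports. "The series", "measured", "known", "first", "only" and "open" are said of these compounds alone.

Measured so far in a functional assay on HEK293 cells for antagonist activity at proteinase-activated receptor 4 (Homo sapiens), read by FLIPR and calcium flux, with a stated time of 30 min; a higher number here means a weaker inhibitor, a lower number a stronger inhibitor:
Compound 1 `COc1cc(OCc2csc(-c3cccc(C(=O)N(C)C)c3)n2)c2cc(-c3cn4nc(OC)sc4n3)oc2c1` gives 0.8 nM.
Compound 2 `COc1cc(OCc2csc(-c3ccc(C(C)(C)O)cc3)n2)c2cc(-c3cn4nc(OC)sc4n3)oc2c1` gives 2.4 nM.
Compound 3 `COc1cc(OCc2csc(-c3ccc(S(C)(=O)=O)cc3)n2)c2cc(-c3cn4nc(OC)sc4n3)oc2c1` gives 0.8 nM.

Compound 3 stands level with compound 1 at the digits reported, and together these two have the lowest numbers of the three. Compound 2 stands apart from it, as the step of a 3.0-fold lower number from compound 2 to compound 3 (0.48 log units; beyond the scatter) shows.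

Compound 4 `COc1cc(OCc2csc(-c3ccc(C(=O)O)cc3)n2)c2cc(-c3cn4nc(OC)sc4n3)oc2c1` differs from compound 3 in one place only: carboxy in place of methylsulfonyl on an aromatic carbon. Within the data shown here, two measured steps bear on this kind of change, since both swap the group carried on the same six-membered ring. The step of no change at the digits printed from compound 1 to compound 3 (within the scatter) exchanged one whole substituted phenyl for another without a shift beyond the scatter. The step of a 3.0-fold lower number from compound 2 to compound 3 (0.48 log units; beyond the scatter) exchanged only the group para to the large group and moved the number modestly. A carboxy has not been tried in this series, so its effect is open; what the two steps show is that such swaps have moved the number by a modest amount at most. A modest rise is therefore the expected outcome, as a 3.8-fold higher number from compound 3 to compound 4 (0.57 log units; beyond the scatter) states, with the possibility of no change at all. The expected value for compound 4 is 3 nM, within a range from 0.8 nM to 15 nM.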

Compound 4, half-maximal inhibitory concentration: 1.1 nM
For compound 4 the middle estimate is 2.7-fold (0.44 log units) above the measured one, and the stated range covers the measured number.
By their numbers in this assay, from the lowest: compounds 1, 3 and 4 (each within the scatter of the next); then compound 2.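

In this assay, carboxy in place of methylsulfonyl gives a 1.4-fold higher number from compound 3 to compound 4 (0.14 log units; within the scatter), so on this ring, para to a large group, a carboxy serves as well as a methylsulfonyl, even though the two differ in hydrogen-bond donors, with one in the carboxy and none in the methylsulfonyl. The same holds against the other low compound, since 4-carboxyphenyl in place of 3-(dimethylcarbamoyl)phenyl gives a 1.4-fold higher number from compound 1 to compound 4 (0.14 log units; within the scatter), while carboxy in place of 1-hydroxy-1-methylethyl gives a 2.2-fold lower number from compound 2 to compound 4 (0.34 log units; beyond the scatter), a modest step that leaves compound 2 as the only one of the four set apart from the rest. Nothing given here accounts for why these different groups yield such close numbers.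

What the compounds shown leave open is how far this tolerance extends, for instance whether an aminomethyl group, a primary amide or a nitrile on the same carbon would also stay level with compound 3 and compound 4. As far as these compounds go, it also remains open whether a carboxy placed where compound 1 carries its dimethylcarbamoyl group would give a similar number in this assay as well.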